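Swapping a triazole for an imidazole on the sulfur

A few compounds are considered here, and "the series" means these few. Any claim that something is new, unique, unknown or untested is made for them only; others in the source may bear on it.

Compound 2 `Cn1cnnc1SCC(=O)Nc1ccc(-c2nc(-c3ccccc3)c(-c3ccccc3)n2C)cc1` stands higher of the two compounds measured in a functional assay on HT-29 cells (Homo sapiens) for cytotoxicity, read by MTT assay, with a stated time of 24 h, tested at 0.64 ug/mL (a lower number here means a weaker effect, a higher number a stronger effect of the compound at the concentration tested), where compound 2 gives 32%. Compound 1 `Cc1ccc2oc(SCC(=O)Nc3ccc(-c4nc(-c5ccccc5)c(-c5ccccc5)n4C)cc3)nc2c1` gives 11%, and the step of a number 21 percentage points higher from compound 1 to compound 2 (beyond the scatter) shows how much a different ring on the sulfur altered the read-out. Compound 3 `Cn1ccnc1SCC(=O)Nc1ccc(-c2nc(-c3ccccc3)c(-c3ccccc3)n2C)cc1` differs from compound 2 in one place: 1-methyl-1H-imidazol-2-yl in place of 4-methyl-4H-1,2,4-triazol-3-yl on a sulfur. Within the data shown here, no measured step covers this particular swap; the single step available concerns another ring and gives only a rough sense of scale. A small fall or none beyond the scatter seems plausible, so the expected step is a number 4 percentage points lower from compound 2 to compound 3 (within the scatter). Compound 3 is therefore estimated at 28%, between 12% and 44%.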

Compound 3, a percentage reported as activity, at one concentration (the size of the read-out at that concentration, not a potency): 13.6%
For compound 3 the middle estimate is 14.4 percentage points above the measured one, within the range that was stated.
By their numbers in this assay, from the lowest: compounds 1 and 3 (each within the scatter of the next); then compound 2.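

The identity of the ring on the sulfur matters even when the heavy-atom count stays the same: in this assay, 1-methyl-1H-imidazol-2-yl in place of 4-methyl-4H-1,2,4-triazol-3-yl gives a number 18.4 percentage points lower from compound 2 to compound 3 (beyond the scatter), a change of one ring nitrogen to carbon. Set against 5-methyl-1,3-benzoxazol-2-yl, the same group gives a number 2.6 percentage points higher from compound 1 to compound 3 (within the scatter), so of these three rings only the triazole stands apart. Nothing shown gives a reason for these differences. From the compounds shown here alone, whether an amine or a carboxylic acid in place of the ring on the sulfur would keep or raise the read-out remains open.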